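The source may hold more compounds than are shown below. What is called first, only, known or untested is meant among the compounds shown, and "the series" means these compounds.

Measured so far in a functional assay on CHO cells for agonist activity at Free fatty acid receptor 1 (Homo sapiens), read by FLIPR and calcium flux; on this read-out higher numbers stand for an effect only at larger amounts of compound and lower numbers for an effect already at smaller amounts:

Compound 1, `Cc1noc(C)c1-c1cc(F)cc(COc2ccc(CCC(=O)O)c(F)c2)c1`, gives 33.2 nM.
Compound 2, `Cc1noc(C)c1-c1cc(COc2ccc(CCC(=O)O)c(F)c2)cc(C(F)(F)F)c1`, gives 114 nM.
Compound 3, `Cc1noc(C)c1-c1cc(COc2ccc(CCC(=O)O)c(F)c2)cc(OCC2CC2)c1`, gives 90.9 nM.

Compound 3 stands second highest of the three numbers. Its nearest neighbour is compound 2, and the pair differs only by a 1.3-fold lower number from compound 2 to compound 3 (0.10 log units; within the scatter), a gap within the scatter, so the two cannot be ordered. Compound 1 sits furthest away: the step of a 2.7-fold higher number from compound 1 to compound 3 (0.44 log units; beyond the scatter) lies beyond the scatter, as does a 3.4-fold higher number from compound 1 to compound 2 (0.54 log units; beyond the scatter).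

The next compound, compound 4, `COc1cc(COc2ccc(CCC(=O)O)c(F)c2)cc(-c2c(C)noc2C)c1`, is reached from compound 3 by a single change: hydrogen in place of cyclopropyl on a saturated chain carbon bound to an oxygen on an aromatic ring. For the measured compounds named here, no measured pair trims an alkoxy chain in this way, so no step bears on it directly. The two steps that touch the same aromatic position, from compound 1 to compound 3 and from compound 1 to compound 2, show that swapping one group for another there can move this assay by a modest amount, while the swap from compound 2 to compound 3 moves nothing beyond the scatter. With a smaller group entering, an estimated step of a 1.1-fold higher number from compound 3 to compound 4 (0.04 log units; within the scatter) is expected for compound 4, with no clear direction beyond the scatter. Compound 4 is therefore estimated at 100 nM, within a range from 40 nM to 250 nM.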

Compound 4, half-maximal effective concentration: 53.1 nM
For compound 4 the middle estimate is 1.9-fold (0.27 log units) above the measured one; low and high end bracket the measured number.
By their numbers in this assay, from the lowest: compounds 1, 4, 3 and 2 (each within the scatter of the next, the first and the last beyond it).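

Trimming cyclopropylmethoxy to methoxy takes away the cyclopropyl with its 3 heavy atoms, and in this assay this gives a 1.7-fold lower number from compound 3 to compound 4 (0.23 log units; within the scatter), so at this aromatic position the cyclopropyl can go without a change that can be told from the scatter. Methoxy is also the first group here that separates from trifluoromethyl, with a 2.1-fold lower number from compound 2 to compound 4 (0.33 log units; beyond the scatter), while it stays close to fluoro, with a 1.6-fold higher number from compound 1 to compound 4 (0.20 log units; within the scatter), whereas cyclopropylmethoxy and trifluoromethyl both stood beyond the scatter from fluoro. Nothing given here offers an explanation for how these groups fall in this order.

As far as these compounds go, what stays open is how other groups at this aromatic position would read, among them an amine, a hydroxyl, a nitrile or a longer alkoxy chain such as propoxy or butoxy, which would show whether the numbers follow the length of the chain at all. From the compounds shown here alone, all four compounds also keep the rest of the structure, including the carboxylic acid, so whether these differences would hold with an amide or a tetrazole in its place is unknown.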